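The source may hold more compounds than are shown below. What is called first, only, known or untested is meant among the compounds shown, and "the series" means these compounds.

Compound 1 `Cc1ccc(-c2nn(CCCCN3CCN(c4cccc(Cl)c4)CC3)c(=O)c3ccccc23)cc1` gives 12.4 nM in an assay on Cerebral cortex for displacement of a labelled ligand from Adrenergic receptor alpha-1 (Rattus norvegicus); on this read-out lower numbers stand for stronger inhibition and higher numbers for weaker inhibition. Compound 2 `Cc1ccc(-c2nn(CCCCN3CCN(c4cccc(C(F)(F)F)c4)CC3)c(=O)c3ccccc23)cc1` differs from compound 1 only by trifluoromethyl in place of chloro on an aromatic carbon; in this assay compound 2 gives 112 nM, and that change reads as a 9.0-fold higher number from compound 1 to compound 2 (0.96 log units; beyond the scatter). Compound 3 `COc1ccccc1N1CCN(CCCCCCCn2nc(-c3ccc(C)cc3)c3ccccc3c2=O)CC1`, carrying a longer chain and a methoxy group on the aromatic ring at the far end, gives 8.4 nM in this assay; its number sits within the scatter of compound 1 and well apart from compound 2, so among these three it is, with compound 1, one of the two lower values.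

Compound 4 `CCOc1ccccc1N1CCN(CCCCCCCn2nc(-c3ccc(C)cc3)c3ccccc3c2=O)CC1` differs from compound 3 by methyl in place of hydrogen on a saturated chain carbon bound to an oxygen on an aromatic ring. For the measured compounds named here, no measured step in this set touches that position: the only step known, from chloro to trifluoromethyl, concerns a different ring and a different kind of group, so it offers no direct guide. Adding one carbon to an alkoxy group is a small change, and the expectation for this assay is therefore a step of a 1.2-fold higher number from compound 3 to compound 4 (0.08 log units; within the scatter), that is, no shift beyond the scatter. Compound 4 is accordingly estimated at 10 nM, within a range from 4 nM to 25 nM.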

Compound 4, inhibition constant: 7.33 nM
Estimate against measurement, compound 4: 1.4-fold (0.13 log units) above, within the range that was stated.
By their numbers in this assay, from the lowest: compounds 4, 3 and 1 (each within the scatter of the next); then compound 2.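

In this assay the step from 2-methoxyphenyl to 2-ethoxyphenyl reads as a 1.1-fold lower number from compound 3 to compound 4 (0.06 log units; within the scatter), so on a saturated chain carbon bound to an oxygen on an aromatic ring, methyl in place of hydrogen leaves the number unchanged within the scatter. For the compounds shown here, this is the first reading at this position, and it differs from the only earlier step, at another place on another pair (a 9.0-fold higher number from compound 1 to compound 2 (0.96 log units; beyond the scatter)), which lay beyond the scatter. No measurement at hand accounts for this result.

The compounds shown leave open whether the number would also hold with a propoxy or isopropoxy group on the aromatic ring, or with a free hydroxyl in place of the alkoxy group. They also leave open whether the 2-ethoxyphenyl group would read the same on the shorter chain of compound 1.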